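Bromo for methoxy on the core: stability outlook

This account rests on a few compounds, and the source may have more. Where it says the series, first, only, none or still open, it means among the compounds named here.

Measured so far:
compound 1, `COc1cc(OC)c(OC)cc1C[S+]([O-])c1ncccc1C(=O)Nc1ccncc1`: < 0.02 h
compound 2, `COc1ccc(C[S+]([O-])c2ncccc2C(=O)Nc2ccncc2)c(OCCO)c1`: < 0.02 h

In an ADME assay (a higher number here means that the compound lasts longer, a lower number that the compound disappears faster), compound 1 gives < 0.02 h, which is a limit of the assay rather than a number. In this assay compound 2 likewise gives < 0.02 h, also a limit. Both values shown thus sit at the limit of < 0.02 h in this assay, at which 2 of the 2 values shown sit, so compound 1 stands at that limit with no numbered value to place it against. For the measured compounds named here, no step between measured compounds can be sized from these two limits.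

Compound 3, `COc1cc(OC)c(C[S+]([O-])c2ncccc2C(=O)Nc2ccncc2)cc1Br`, is not yet measured in this assay. It differs from compound 1 by bromo in place of methoxy on an aromatic carbon. The two limits shown give no direction for such a change, and no step beyond the scatter is expected in this assay. Compound 3 is expected to give about 0.02 h in this assay, within 0.01 h to 0.08 h. The step that this estimate means, a number no lower from compound 1 to compound 3 (the limit leaves the size open), is expected to stay within the scatter, most likely again as a limit.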

Compound 3, half-life: 0.07 h
For compound 3 the middle estimate is 3.5-fold (0.54 log units) below the measured one, and the stated range covers the measured number.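

In this assay, bromo in place of methoxy on this aromatic carbon gives an at least 3.5-fold higher number from compound 1 to compound 3 (0.54 log units; beyond the scatter). Compound 3 is thus the only compound shown with a number rather than a limit: the limit of < 0.02 h in this assay, at which 2 of the 3 values shown sit. Going by these compounds, this carbon, ortho to a methoxy group and para to a methoxy group, is therefore a place where one change on the core of compound 1 lifts the read-out off that limit, and the full size of the step stays open, as the value for compound 1 is a limit.

The compounds shown do not tell whether the step belongs to the arrival of bromo or to the loss of methoxy, and they give no cause for it. On these data alone, whether chloro, a nitrile or an amine on the same carbon would behave like bromo also stays open.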